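This account rests on a few compounds, and the source may have more. Where it says the series, first, only, none or still open, it means among the compounds named here.

Compound 1 `ClCc1ccc(Cn2cnc3c(Cl)ncnc32)cc1`: 32400 nM
Compound 2 `Nc1nc(Cl)c2ncn(Cc3ccc(CCl)cc3)c2n1`: 91200 nM
Compound 3 `ClCc1ccccc1Cn1cnc2c(Cl)ncnc21`: 20000 nM

All three were tested in a functional assay on HOP-62 cells (Homo sapiens) for cytotoxicity, read by sulforhodamine B assay, with a stated time of 48 h; on this read-out higher numbers stand for lower toxicity in this test and lower numbers for higher toxicity in this test. Among the measured compounds shown here, compound 1 gives 32400 nM and compound 2 gives 91200 nM; the single change between them, (amino in place of hydrogen on an aromatic carbon), made a 2.8-fold higher number from compound 1 to compound 2 (0.45 log units; beyond the scatter). Compound 3 gives 20000 nM; it is built from the same atoms as compound 1 joined differently, and the difference between the two cores is not broken down here. Compound 4 `Nc1nc(Cl)c2ncn(Cc3ccccc3CCl)c2n1` has not yet been measured in this assay. It differs from compound 3 by amino in place of hydrogen on an aromatic carbon, which is the same change as the one seen earlier, at the same place. If the amino group acts alike on the core of compound 3, the step is expected to be a 2.8-fold higher number from compound 3 to compound 4 (0.45 log units; beyond the scatter), resting on the single earlier step of a 2.8-fold higher number from compound 1 to compound 2 (0.45 log units; beyond the scatter). Compound 4 is therefore estimated at 56000 nM, between 25000 nM and 125000 nM.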

Compound 4, concentration lethal to 50% of the cells: > 100000 nM
Compound 4: no number, only a limit; the forecaster's own chance of this, stated with the estimate: 10%; at least 1.7-fold (0.25 log units) between middle value and limit.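

In this assay, amino in place of hydrogen on an aromatic carbon again gives a higher number, with an at least 5.0-fold higher number from compound 3 to compound 4 (0.69 log units; beyond the scatter), so the direction of the change holds on both cores shown. Compound 4 gives > 100000 nM, which is a limit of the assay and not a number. The size of the step on this core therefore stays unknown, and two cores cannot establish a general rule, so a matching effect is not shown: the same change on two cores in this assay, a 2.8-fold higher number (0.45 log units; beyond the scatter) from compound 1 to compound 2 and an at least 5.0-fold higher number (0.69 log units; beyond the scatter) from compound 3 to compound 4; the limit leaves it open whether they differ

The compounds shown leave open whether a hydroxyl or a methylamino group in the same place would shift the number in the same direction. They also leave open whether the amino change behaves alike on any further core.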